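This account rests on a few compounds, and the source may have more. Where it says the series, first, only, none or still open, it means among the compounds named here.

Compound 1 `CC[C@](C)(O)CC(=O)O[C@H](CC=C(C)C)C1=CC(=O)c2c(O)ccc(O)c2C1=O`: 20500 nM
Compound 2 `CC(C)=CC[C@@H](OC(=O)CC(O)c1ccccc1)C1=CC(=O)c2c(O)ccc(O)c2C1=O`: 17000 nM
Compound 3 `CC(C)=CC[C@@H](OC(=O)CC(C)(O)C(C)C)C1=CC(=O)c2c(O)ccc(O)c2C1=O`: 16900 nM
Compound 4 `CC(C)=CC[C@@H](OC(=O)CC(C)(O)c1ccccc1)C1=CC(=O)c2c(O)ccc(O)c2C1=O`: not yet measured

All three values come from a functional assay on DU-145 cells (Homo sapiens) for cytotoxicity, read by MTT assay; on this read-out lower numbers stand for stronger inhibition and higher numbers for weaker inhibition. The side chains of the three measured compounds differ, yet every step among them stays within the scatter: a 1.2-fold lower number from compound 1 to compound 2 (0.08 log units; within the scatter), a 1.2-fold lower number from compound 1 to compound 3 (0.08 log units; within the scatter) and a 1.0-fold lower number from compound 2 to compound 3 (0.00 log units; within the scatter). Compound 3, at 16900 nM, therefore stands level with both other compounds, and the set shows no order.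

The next step keeps the rest of compound 3 and alters one group: phenyl in place of isopropyl on a saturated chain carbon bound to an oxygen on a saturated carbon and two saturated chain carbons. In words, phenyl takes the place of isopropyl on a saturated chain carbon bound to an oxygen on a saturated carbon and two saturated chain carbons.

Going by the values given here, no measured step makes exactly this exchange. The closest is a 1.0-fold lower number from compound 2 to compound 3 (0.00 log units; within the scatter), where 1-hydroxy-1,2-dimethylpropyl replaces hydroxy(phenyl)methyl, so a group carrying phenyl gives way to one without it. That step lies within the scatter, as do a 1.2-fold lower number from compound 1 to compound 2 (0.08 log units; within the scatter) and a 1.2-fold lower number from compound 1 to compound 3 (0.08 log units; within the scatter). These three compounds are a small basis, but they give no reason to expect a step beyond the scatter in this assay, in either direction.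

The estimated 1.1-fold lower number from compound 3 to compound 4 (0.02 log units; within the scatter) is accordingly no real change. For compound 4 the expected value is 16000 nM, with an estimated range of 8500 nM to 30000 nM.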

Compound 4, half-maximal inhibitory concentration: > 100000 nM
Compound 4 was reported as a limit; the forecaster's own chance of this, stated with the estimate: 3%; at least 6.2-fold (0.79 log units) between middle value and limit.
By their numbers in this assay, from the lowest: compounds 3, 2 and 1 (each within the scatter of the next). At a limit, above all of these: compound 4.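

In this assay compound 4 is reported only as a limit, not as a number: the limit of > 100000 nM in this assay, at which 1 of the 4 values shown sits.

Even read against that limit, this side chain now shows steps beyond the scatter: an at least 5.9-fold higher number from compound 3 to compound 4 (0.77 log units; beyond the scatter) with phenyl in place of isopropyl, an at least 5.8-fold higher number from compound 2 to compound 4 (0.76 log units; beyond the scatter) with methyl in place of hydrogen, and an at least 4.8-fold higher number from compound 1 to compound 4 (0.68 log units; beyond the scatter) with 1-hydroxy-1-phenylethyl in place of 1-hydroxy-1-methylpropyl. The position is therefore not indifferent to its substituents, as compounds 1, 2 and 3 alone suggested: phenyl with hydrogen on this carbon in compound 2 and methyl with a saturated chain group in compounds 1 and 3 stay within the scatter of each other, and only phenyl together with methyl on the same carbon, in compound 4, breaks from them.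

As far as these compounds go, the full size of these steps stays open. The compounds shown give only a limit and no measured property. A cyclohexyl group or a pyridyl ring in place of phenyl, with the methyl kept, would show whether the change depends on the phenyl ring itself.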